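This account rests on a few compounds, and the source may have more. Where it says the series, first, only, none or still open, it means among the compounds named here.

Measured in a functional assay on MKN-45 cells (Homo sapiens) for cytotoxicity, read by MTT assay, with a stated time of 72 h; on this read-out lower numbers stand for stronger inhibition and higher numbers for weaker inhibition:
compound 1 `COc1cc2c(Oc3ccc(NC(=O)c4cn(-c5ccc(Br)cc5)nn4)cc3F)ccnc2cc1OCCCN1CCCC1` gives 120 nM
compound 2 `COc1cc2c(Oc3ccc(NC(=O)c4cn(-c5c(C)cccc5C)nn4)cc3F)ccnc2cc1OCCCN1CCCC1` gives 3490 nM

Compound 1 stands at the lowest of the two numbers in this assay; the one step shown, a 29-fold higher number from compound 1 to compound 2 (1.46 log units; beyond the scatter), changes the group on the aromatic nitrogen. Compound 3 `COc1cc2c(Oc3ccc(NC(=O)c4cn(-c5ccc(Br)cc5)nn4)cc3F)ccnc2cc1OCCCN1CCCCC1` differs from compound 1 elsewhere: piperidin-1-yl in place of pyrrolidin-1-yl on a saturated chain carbon, three bonds along the chain from an oxygen on an aromatic ring. Among the measured compounds shown here, no measured step bears on this change, since the step between compound 1 and compound 2 alters a different place. For compound 3 the expected step is therefore no change at the digits printed from compound 1 to compound 3 (within the scatter), no more than the scatter. Compound 3 is thus estimated at 120 nM, with a range from 50 nM to 300 nM.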

Compound 3, half-maximal inhibitory concentration: 150 nM
Compound 3: middle estimate off by 1.3-fold (0.10 log units), on the low side; the range from low to high includes it.
By their numbers in this assay, from the lowest: compounds 1 and 3 (each within the scatter of the next); then compound 2.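

In this assay, piperidin-1-yl in place of pyrrolidin-1-yl on the propyl chain gives a 1.3-fold higher number from compound 1 to compound 3 (0.10 log units; within the scatter) and so leaves the read-out within the scatter. Among the compounds shown here, this is the first reading at this end of the molecule, and it shows that these two saturated rings cannot be told apart here while 4-bromophenyl stays on the aromatic nitrogen. No evidence is available to explain this result. Going by these compounds, whether a morpholine ring or a dimethylamino group at this place would read the same remains open. So does whether a shorter chain, such as 2-(piperidin-1-yl)ethyl, would keep this level.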